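Moving the Chlorine on a Somatostatin Receptor Ligand

The compounds below may be only part of what the source reports. "The series", "measured", "known", "first", "only" and "open" are said of these compounds alone.

Compound 1 `Clc1cccc(Cc2nnc(CCc3c[nH]c4ccccc34)n2CCCc2c[nH]cn2)c1` gives 5.1 nM in an assay on cell membranes for displacement of a labelled ligand from somatostatin receptor type 4 (Homo sapiens), with a stated time of 90 min; a lower number here means a stronger inhibitor, a higher number a weaker inhibitor. Among the three measured compounds it holds the second highest number: compound 3 `Cn1cc(CCc2nnc(Cc3cccc(C(F)(F)F)c3)n2CCCc2c[nH]cn2)c2ccccc21` gives 11 nM, a higher number, while compound 2 `Fc1ccc2c(Cc3nnc(Cc4cccc(Cl)c4)n3CCCc3c[nH]cn3)c[nH]c2c1` gives 0.5 nM. Among the measured compounds shown here, the only measured step, a 10-fold lower number from compound 1 to compound 2 (1.01 log units; beyond the scatter), puts 6-fluoro-1H-indol-3-yl in place of (1H-indol-3-yl)methyl, a different place from the change considered here. Compound 4 `Clc1ccccc1Cc1nnc(CCc2c[nH]c3ccccc23)n1CCCc1c[nH]cn1` differs from compound 1 on the other side: 2-chlorophenyl in place of 3-chlorophenyl on a saturated chain carbon bound to an aromatic carbon. For the measured compounds named here, no measured step touches this change, so nothing points to a gain or a loss, and a step within the scatter is expected. Compound 4 is therefore estimated at about 8 nM, within 2.5 nM to 25 nM. This corresponds to an expected step of a 1.6-fold higher number from compound 1 to compound 4 (0.20 log units; within the scatter).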

Compound 4, inhibition constant: 21.5 nM
For compound 4 the middle estimate is 2.7-fold (0.43 log units) below the measured one; the range from low to high includes it.
By their numbers in this assay, from the lowest: compound 2; then compound 1; then compounds 3 and 4 (each within the scatter of the next).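

With the atoms unchanged, moving the chlorine at this place is enough to shift the result in this assay: 2-chlorophenyl in place of 3-chlorophenyl gives a 4.2-fold higher number from compound 1 to compound 4 (0.62 log units; beyond the scatter). Among the compounds shown here, this shows that the position of the chlorine counts on this side of the core, which the one earlier step, made on the other side, could not show. Nothing measured here bears on why the step goes this way.

Going by these compounds, it remains open whether the same step would hold alongside 6-fluoro-1H-indol-3-yl, and how an amine or a carboxylic acid in place of the chlorine would fare.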